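A Methyl Added to a Chain at the Assay Limit

The source may report more compounds than this note shows. Statements on the series, on what has been measured and on what is new or still open speak of the compounds shown alone.

Compound 1 `CC(C)(C)CCn1nc(-c2cccs2)c(O)c(C2=NS(=O)(=O)c3cc(NS(C)(=O)=O)ccc3N2)c1=O`: > 1000 nM
Compound 2 `CC(C)Cn1nc(-c2cccs2)c(O)c(C2=NS(=O)(=O)c3cc(NS(C)(=O)=O)ccc3N2)c1=O`: > 1000 nM

Both entries come from an ADME assay on Huh-7 cells (Homo sapiens) for cytotoxicity, with a stated time of 72 h; on this read-out higher numbers stand for lower toxicity in this test and lower numbers for higher toxicity in this test. In this assay compound 2 gives > 1000 nM, which is a limit and not a number. Compound 1 gives > 1000 nM, which is also a limit. The whole record so far is the limit of > 1000 nM in this assay, at which 2 of the 2 values shown sit.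

Compound 3 `CC(C)(C)Cn1nc(-c2cccs2)c(O)c(C2=NS(=O)(=O)c3cc(NS(C)(=O)=O)ccc3N2)c1=O` has not yet been measured. Its difference from compound 2 is methyl in place of hydrogen on a saturated chain carbon bound to three saturated chain carbons. Put simply, methyl takes the place of hydrogen on a saturated chain carbon bound to three saturated chain carbons, so isobutyl becomes neopentyl.

Among the compounds with values here, the only measured step bearing on this change is a step that the two limits leave unreadable from compound 1 to compound 2. With no readable size, that step gives no reason to expect a change in either direction, so no step beyond the scatter is expected. Compound 3 is therefore expected to stay in the same region of this assay, and the assay may well report only a limit again. The expected step is a step that the limit leaves unreadable from compound 2 to compound 3. For compound 3 the estimated value is 2000 nM, with an expected range from 1000 nM to 10000 nM.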

Compound 3, half-maximal cytotoxic concentration: > 1000 nM
Compound 3 gave a limit, no number (the forecaster's own chance of this, stated with the estimate: 90%); the middle value does not contradict the limit.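

In this assay, no step can be read among compound 1, compound 2 and compound 3, because each result is a limit and not a number: the limit of > 1000 nM in this assay, at which 3 of the 3 values shown sit.

The compounds shown leave open whether changing the chain group alters the read-out at all, and what the actual values of these three compounds are.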